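The compounds below may be only part of what the source reports. "The series", "measured", "known", "first", "only" and "open" are said of these compounds alone.

Measured in an ADME assay on microsomes from liver (Mus musculus) for metabolic stability, read by mass spectrometry, with a stated time of 40 min, tested at 1 uM; a higher number here means that more of the compound is left, a lower number that less of the compound is left:
- Compound 1 `COc1cc(N2CCC(C(=O)N3CCC(N(C)C)C3)CC2)ccc1Nc1nc(NC2CCCCC2)c2nc[nH]c2n1`: 60%
- Compound 2 `CCN(CC)CC1CCN(c2ccc(Nc3nc(NC4CCCCC4)c4nc[nH]c4n3)c(OC)c2)CC1`: 47%
- Compound 3 `COc1cc(N2CCC(CC(=O)N3CCC(N(C)C)C3)CC2)ccc1Nc1nc(NC2CCCCC2)c2nc[nH]c2n1`: 48%

Compound 3, at 48%, is level with compound 2 and lies under compound 1. The next compound, compound 4 `COc1cc(N2CCC(CC(=O)N3CCCC3)CC2)ccc1Nc1nc(NC2CCCCC2)c2nc[nH]c2n1`, carries hydrogen in place of dimethylamino on a saturated ring carbon. The side chain becomes ((pyrrolidin-1-yl)carbonyl)methyl.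

Going by the values given here, no measured step removes this group alone, so the evidence is indirect. Side-chain changes gave a number 13 percentage points lower from compound 1 to compound 2 (beyond the scatter) and a number 12 percentage points lower from compound 1 to compound 3 (beyond the scatter), both modest, while a number 1 percentage points higher from compound 2 to compound 3 (within the scatter) stayed within the scatter. These steps suggest that changes in this part of the molecule move this assay modestly or not at all, and they fix no direction. A small downward step is tentatively expected, and a result level with compound 3 would not be surprising. The expected step is a number 6 percentage points lower from compound 3 to compound 4 (within the scatter). For compound 4 the estimated value is 42%, with an expected range of 25% to 60%.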

Compound 4, percent of the compound remaining: 59%
Estimate against measurement, compound 4: 17 percentage points below; the range from low to high includes it.
By their numbers in this assay, from the lowest: compounds 2 and 3 (each within the scatter of the next); then compounds 4 and 1 (each within the scatter of the next).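

Hydrogen in place of dimethylamino on this saturated ring carbon, two ring bonds from the ring nitrogen, gives in this assay a number 11 percentage points higher from compound 3 to compound 4 (beyond the scatter), the first direct reading of this change, and it shows that the group can go without a loss in compound remaining. The other steps place the new side chain among the earlier ones: a number 12 percentage points higher from compound 2 to compound 4 (beyond the scatter) for (pyrrolidin-1-yl)carbonyl in place of diethylamino, and a number 1 percentage points lower from compound 1 to compound 4 (within the scatter) for ((pyrrolidin-1-yl)carbonyl)methyl in place of (3-(dimethylamino)pyrrolidin-1-yl)carbonyl. Nothing at hand accounts for these movements.

As far as these compounds go, whether the step belongs to dimethylamino in particular remains open, and a hydroxyl or a methyl on the same ring carbon would bear on that. From the compounds shown here alone, it is also open whether the step would recur with the (pyrrolidin-1-yl)carbonyl group directly on the saturated ring carbon, without the methylene link.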